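The compounds below may be only part of what the source reports. "The series", "measured", "known", "first", "only" and "open" are said of these compounds alone.

Values so far in a functional assay on HeLa cells (Homo sapiens) for cytotoxicity, read by MTT assay, with a stated time of 48 h; on this read-out higher numbers stand for weaker inhibition and lower numbers for stronger inhibition
- compound 1 `CC1(C)CCC[C@]2(C)[C@@H](CC[C@@](C)(O)/C=C/c3cncc4ccccc34)[C@](C)(O)CC[C@@H]12` gives 46000 nM
- compound 2 `CC1(C)CCC[C@]2(C)[C@@H](CC[C@@](C)(O)/C=C/c3ccc(Br)cc3)[C@](C)(O)CC[C@@H]12` gives 45900 nM

For the measured compounds named here, compound 2 stands level with compound 1, the only other measured member of the series, and the two values cannot be separated. Next is compound 3 `CC1(C)CCC[C@]2(C)[C@@H](CC[C@@](C)(O)/C=C/c3ccc(F)cc3)[C@](C)(O)CC[C@@H]12` with fluoro in place of bromo on an aromatic carbon, para to a large group. Going by the values given here, no measured step isolates a halogen exchange. Among the compounds with values here, the one step bearing on it, a 1.0-fold lower number from compound 1 to compound 2 (0.00 log units; within the scatter), exchanged the whole aromatic group and stayed within the scatter. On that single step, the exchange on the ring of compound 2 is also expected to stay within the scatter in this assay, with no direction favoured. The expected step is a 1.0-fold higher number from compound 2 to compound 3 (0.01 log units; within the scatter). For compound 3 the estimated value is 47000 nM, with an expected range from 25000 nM to 88000 nM.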

Compound 3, half-maximal inhibitory concentration: 3460 nM
Compound 3: the middle estimate sits 14-fold (1.13 log units) above what was measured; the whole stated range lies above it.
By their numbers in this assay, from the lowest: compound 3; then compounds 2 and 1 (each within the scatter of the next).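

In this assay, for the compounds shown here, the aromatic carbon para to a large group proves sensitive to a single-atom exchange: fluoro in place of bromo gives a 13-fold lower number from compound 2 to compound 3 (1.12 log units; beyond the scatter) and is the first step beyond the scatter. The aromatic group as a whole also matters once it carries fluoro, with 4-fluorophenyl in place of isoquinolin-4-yl giving a 13-fold lower number from compound 1 to compound 3 (1.12 log units; beyond the scatter) even though 4-bromophenyl in the same exchange gave a 1.0-fold lower number from compound 1 to compound 2 (0.00 log units; within the scatter) and stayed within the scatter. No evidence in hand accounts for the gap between fluoro and bromo at this position.

On these data alone, two halogens define no trend, so whether chloro, methoxy or a plain phenyl would sit with compound 3 or with compound 2 stays open. Also open, as far as these compounds go, is whether fluoro gives a similar step at another carbon of the ring.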